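A few compounds are considered here, and "the series" means these few. Any claim that something is new, unique, unknown or untested is made for them only; others in the source may bear on it.

Three compounds have been measured in a functional assay on BGC-823 cells (Homo sapiens) for inhibition, read by CCK-8 assay, with a stated time of 48 h; on this read-out higher numbers stand for weaker inhibition and lower numbers for stronger inhibition:

Compound 1, `COc1ccc(C2=NN(C3=NC(c4ccccc4)CS3)C(c3cccc4ccccc34)C2)cc1`, gives 9510 nM.
Compound 2, `COc1ccc(C2=NN(C3=NC(c4ccccc4)CS3)C(c3ccc4ccccc4c3)C2)cc1`, gives 7250 nM.
Compound 3, `O=C1CSC(N2N=C(c3ccc(F)cc3)CC2c2ccc3ccccc3c2)=N1`, gives 14900 nM.

Among these three numbers compound 1 holds the second highest. Going by the values given here, its nearest neighbour is compound 2, and the single step that has been measured between neighbours, a 1.3-fold lower number from compound 1 to compound 2 (0.12 log units; within the scatter), lies within the scatter. Compound 3 differs from compound 1 in more than one place, so its number can only be set beside that of compound 1, and the two lie within the scatter of each other.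

Compound 4, `Brc1ccc(C2=NN(C3=NC(c4ccccc4)CS3)C(c3cccc4ccccc34)C2)cc1`, has not yet been measured. It differs from compound 1 by bromo in place of methoxy on an aromatic carbon. Among the compounds with values here, none of the measured steps concerns this change: the only measured step swaps naphthalen-2-yl for naphthalen-1-yl on a saturated ring carbon and leaves the methoxy untouched. Within the data shown here, with no step bearing on the change, no movement beyond the scatter is expected in this assay. Compound 4 is therefore estimated at 9500 nM, with a range from 3500 nM to 26000 nM. The expected step is a 1.0-fold lower number from compound 1 to compound 4 (0.00 log units; within the scatter), that is, none beyond the scatter.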

Compound 4, half-maximal inhibitory concentration: 17400 nM
Compound 4: the middle estimate sits 1.8-fold (0.26 log units) below what was measured; the range from low to high includes it.
By their numbers in this assay, from the lowest: compounds 2, 1, 3 and 4 (each within the scatter of the next, the first and the last beyond it).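

In this assay, putting bromo in place of methoxy on the aromatic carbon gives a 1.8-fold higher number from compound 1 to compound 4 (0.26 log units; within the scatter) and so does not shift the number beyond the scatter of repeated measurements. For this one pair, then, the 4-methoxyphenyl and 4-bromophenyl versions of the core of compound 1 cannot be told apart, even though bromo has fewer heavy atoms and no hydrogen-bond acceptor, whereas methoxy has one. Nothing shown gives a reason for this result.

As far as these compounds go, whether an amine, a carboxylic acid or a longer chain at this position would move the number beyond the scatter remains open. Also open, from the compounds shown here alone, is whether bromo in place of methoxy would read the same with naphthalen-2-yl in place of naphthalen-1-yl on the saturated ring carbon.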